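Styrene Replaces Aminomethyl on the Oxadiazole of Compound 3

The source may report more compounds than this note shows. Statements on the series, on what has been measured and on what is new or still open speak of the compounds shown alone.

Three compounds share one core. Compound 1 `NS(=O)(=O)c1cc(-c2nnc(CN3CCC(Cc4ccccc4)CC3)o2)c(Cl)cc1SCc1ccccc1` gives 19000 nM in a functional assay on HCT-116 cells (Homo sapiens) for cytotoxicity, read by MTT assay, with a stated time of 72 h; on this read-out lower numbers stand for stronger inhibition and higher numbers for weaker inhibition. Compound 2 `COc1ccc(-c2cn(Cc3nnc(-c4cc(S(N)(=O)=O)c(SCc5ccccc5)cc4Cl)o3)nn2)cc1` gives 190000 nM in this assay. Compound 3 `NCc1nnc(-c2cc(S(N)(=O)=O)c(SCc3ccccc3)cc2Cl)o1` gives 120000 nM in this assay, which places it second highest of the three numbers: its gap to compound 2 lies within the scatter, while compound 1 stands well lower, beyond the scatter. Compound 4 `NS(=O)(=O)c1cc(-c2nnc(/C=C/c3c(Cl)cccc3Cl)o2)c(Cl)cc1SCc1ccccc1` has not yet been measured; it differs from compound 3 by 2-(2,6-dichlorophenyl)ethenyl in place of aminomethyl on an aromatic carbon. For the measured compounds named here, no single-change step between measured compounds is known, so the size of this step is uncertain. Because compound 1 shows 19000 nM with a large group at that same position, a lower number is expected for compound 4, a step of a 3.0-fold lower number from compound 3 to compound 4 (0.48 log units; beyond the scatter) of moderate size. The estimate for compound 4 is 40000 nM, with a range from 8000 nM to 200000 nM.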

Compound 4, half-maximal inhibitory concentration: 32000 nM
For compound 4 the middle estimate is 1.3-fold (0.10 log units) above the measured one; the measured number falls inside the stated range.
By their numbers in this assay, from the lowest: compounds 1 and 4 (each within the scatter of the next); then compounds 3 and 2 (each within the scatter of the next).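

In this assay, for the compounds shown here, 2-(2,6-dichlorophenyl)ethenyl in place of aminomethyl gives a 3.8-fold lower number from compound 3 to compound 4 (0.57 log units; beyond the scatter), the first single-change step that can be read at this position. The lower number therefore does not need the aminomethyl group, since the entering group has no hydrogen-bond donor or acceptor. Nothing measured here explains the step.

On these data alone, whether the step comes from the ethenyl link or from the two chlorine atoms stays open. A plain 2-phenylethenyl group or a saturated 2-phenylethyl chain on this carbon would separate the two.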